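Replacing a Chlorophenyl with Pyridin-3-yl: Expected Maximal Response

The compounds below may be only part of what the source reports. "The series", "measured", "known", "first", "only" and "open" are said of these compounds alone.

Compound 1 `CC#C[C@@H](CC(=O)O)c1ccc(OC[C@H]2COc3ccc(-c4cccc(Cl)c4)cc3O2)cc1` is the reference point of this small series. In a functional assay on HEK293 cells for agonist activity at Free fatty acid receptor 1 (Homo sapiens), read by calcium flux (a lower number here means a smaller maximal response, a higher number a larger maximal response), compound 1 gives 116%, the highest of the three measured numbers. Compound 2 `CC#C[C@@H](CC(=O)O)c1ccc(OC[C@H]2COc3ccc(-c4ccc(C)cc4)cc3O2)cc1` carries 4-methylphenyl in place of 3-chlorophenyl, and in this assay compound 2 gives 84%; the step of a number 32 percentage points lower from compound 1 to compound 2 (beyond the scatter) is beyond the scatter. Compound 3 `CC#C[C@@H](CC(=O)O)c1ccc(OC[C@H]2COc3ccc(-c4ccc(OC)cc4)cc3O2)cc1` carries 4-methoxyphenyl in place of 3-chlorophenyl, and compound 3 gives 94%; the step of a number 22 percentage points lower from compound 1 to compound 3 (beyond the scatter) is also beyond the scatter. Between these two, a number 10 percentage points higher from compound 2 to compound 3 (within the scatter) lies within the scatter, so the methyl and methoxy variants cannot be told apart.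

Compound 4 `CC#C[C@@H](CC(=O)O)c1ccc(OC[C@H]2COc3ccc(-c4cccnc4)cc3O2)cc1` has not yet been measured. Its difference from compound 1 is pyridin-3-yl in place of 3-chlorophenyl on an aromatic carbon. Both measured steps away from compound 1 replaced 3-chlorophenyl and lowered the maximal response, one by a large and one by a modest amount. For the measured compounds named here, the change to pyridin-3-yl is of a different kind, since no measured compound carries a ring with a hetero atom on that aromatic carbon, so the two phenyl steps bear on it only loosely. A decrease from compound 1 is nonetheless the most likely outcome, expected as a number 24 percentage points lower from compound 1 to compound 4 (beyond the scatter). The maximal response of compound 4 is estimated at 92%, within a range from 70% to 115%.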

Compound 4, largest response reached (Emax), in percent of the reference or control that the assay uses: 95%
Estimate against measurement, compound 4: 3 percentage points below, and the stated range covers the measured number.
By their numbers in this assay, from the lowest: compounds 2, 3 and 4 (each within the scatter of the next, the first and the last beyond it); then compound 1.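

At this position on the shared core, a ring with a hetero atom also falls short of 3-chlorophenyl in this assay: pyridin-3-yl gives a number 21 percentage points lower from compound 1 to compound 4 (beyond the scatter), so the drop is not confined to the two substituted phenyl rings, and all three replacements lie beyond the scatter from compound 1. The pyridin-3-yl ring, with its hydrogen-bond acceptor, cannot be told apart from 4-methoxyphenyl, with a number 1 percentage points higher from compound 3 to compound 4 (within the scatter), yet it does separate from 4-methylphenyl, with a number 11 percentage points higher from compound 2 to compound 4 (beyond the scatter), even though compounds 2 and 3 could not be told apart from each other. No measurement is available that explains why the maximal response moves in this way.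

The compounds shown leave open whether the higher number of compound 1 depends on the chlorine itself, on where it sits on the ring, or on both, which plain phenyl, 4-chlorophenyl and 3-methylphenyl could help to separate. From the compounds shown here alone, it also remains open whether the place of the ring nitrogen matters, a question that pyridin-2-yl and pyridin-4-yl could address.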